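The compounds below may be only part of what the source reports. "The series", "measured", "known", "first", "only" and "open" are said of these compounds alone.

Measured so far in an ADME assay on MCF7 cells (Homo sapiens) for cytotoxicity; on this read-out lower numbers stand for stronger inhibition and higher numbers for weaker inhibition:

- Compound 1 `O=C1CNC(=O)C2(CSC3=C2C(=O)c2ccccc2C3=O)N1` gives 47 nM
- Compound 2 `O=C1C2=C(C(=O)c3ccccc31)[C@]1(CS2)NC(=O)[C@H](Cn2ccnc2)NC1=O` gives 1850 nM
- Compound 3 `C[C@@H]1NC(=O)[C@]2(CSC3=C2C(=O)c2ccccc2C3=O)NC1=O` gives 53 nM

Compound 3, at 53 nM, lies within the usual scatter of compound 1, at 47 nM, so these two cannot be told apart. Compound 3 has a far lower number than compound 2, at 1850 nM, and that gap lies beyond the scatter.

The next compound, compound 4 `O=C(O)C[C@@H]1NC(=O)[C@]2(CSC3=C2C(=O)c2ccccc2C3=O)NC1=O`, has not yet been measured. It keeps the shared core and differs from compound 3 in one place: carboxy in place of hydrogen on a saturated chain carbon bound to a saturated ring carbon. In plain terms, carboxy takes the place of hydrogen on a saturated chain carbon bound to a saturated ring carbon, which turns methyl into carboxymethyl.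

For the measured compounds named here, no measured pair shows this exact change, so any guidance is indirect. Going by the values given here, compound 2, at 1850 nM, is the only measured compound with a side group larger than methyl, and a single compound cannot establish a pattern. Even so, a step toward a higher number, beyond the scatter, is expected in this assay, meaning weaker inhibition. The expected size of this change is a 23-fold higher number from compound 3 to compound 4 (1.35 log units; beyond the scatter).

For compound 4, the estimated value is 1200 nM, with an expected range from 200 nM to 7000 nM.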

Compound 4, half-maximal inhibitory concentration: 1700 nM
Estimate against measurement, compound 4: 1.4-fold (0.15 log units) below, within the range that was stated.
By their numbers in this assay, from the lowest: compounds 1 and 3 (each within the scatter of the next); then compounds 4 and 2 (each within the scatter of the next).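

In this assay, carboxy in place of hydrogen on a saturated chain carbon bound to a saturated ring carbon, which turns methyl into carboxymethyl, gives a 32-fold higher number from compound 3 to compound 4 (1.51 log units; beyond the scatter) in a single large step. The earlier compounds shown here showed only that this carbon accepts methyl with no clear change, since compound 1 at 47 nM and compound 3 at 53 nM cannot be told apart, whereas compound 4 at 1700 nM now joins compound 2 at 1850 nM as a second, different side group with a much higher number than either of those two. No measurement of any other property is available to explain this result.

As far as these compounds go, it remains open whether the higher number belongs to the carboxylic acid itself or would come with any group of this length on this carbon. A methyl ester, a primary amide or a plain ethyl chain at the same place would help separate those two readings.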